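The source may report more compounds than this note shows. Statements on the series, on what has been measured and on what is new or still open speak of the compounds shown alone.

Working notes on the series, read in a functional assay on CCRF-CEM cells (Homo sapiens) for cytotoxicity; on this read-out lower numbers stand for stronger inhibition and higher numbers for weaker inhibition. Compound 1 (`COc1ccc(NS(=O)(=O)c2ccc3c(c2)CCN3C)c(OC)n1`) reports only a limit, > 2000 nM. Compound 2 (`COc1ccc(NS(=O)(=O)c2ccc3c(ccn3C)c2)c(OC)n1`) gives a measured number, 712 nM, the only one available so far. Compound 3 (`COc1ccc(/C=C/c2ccc(OC)c(O)c2)c(OC)n1`) also reports only a limit, > 2000 nM. Its true potency is therefore unknown, and it stands at the limit of > 2000 nM in this assay, at which 2 of the 3 values shown sit.

The next compound is compound 4 (`COc1ccc(/C=C\c2ccc(OC)c(O)c2)c(OC)n1`). It has the same atoms and bonds as compound 3 and differs only in configuration as drawn: the two compounds have the same atoms and bonds and differ only in configuration as drawn: 1 of 1 stereo elements differ; a double bond is drawn E in compound 3 and Z in compound 4. The double bond is drawn E in compound 3 and Z in compound 4.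

For the measured compounds named here, no pair of measured compounds differs in one place, so the data give no direct size for this step. The starting point is also only a limit, so any step can be sized only approximately. A clear shift toward stronger inhibition is expected nonetheless, beyond the usual scatter, though this remains an expectation with wide uncertainty. The estimated change is an at least 33-fold lower number from compound 3 to compound 4 (1.52 log units; beyond the scatter). For compound 4 the expected value is 60 nM, with an estimated range of 8 nM to 800 nM.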

Compound 4, half-maximal inhibitory concentration: 342 nM
The estimate for compound 4 lay 5.7-fold (0.76 log units) below the measured number, within the range that was stated.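

In this assay the series now has its first step between two compounds that differ in one place, and that step is an at least 5.8-fold lower number from compound 3 to compound 4 (0.76 log units; beyond the scatter). Compound 3 reports only a limit, > 2000 nM, so the step gives a lower bound on the change and not its full size. The shift can be assigned to configuration alone, because nothing else separates the pair, and the double bond drawn Z in compound 4 is the form that gives the stronger inhibition of these two: the fact that compounds 3 and 4 differ only in the configuration as drawn.

Going by these compounds, the true size of the step remains open, as does whether the Z double bond would give a similar shift on another core, such as that of compound 1 or compound 2, neither of which has a partner here that differs from it in one place. Also open, on these data alone, is how the Z form would respond if its hydroxyl group gave way to an amine or a fluorine atom, or if one of its methoxy groups gave way to a longer ether chain.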